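A few compounds are considered here, and "the series" means these few. Any claim that something is new, unique, unknown or untested is made for them only; others in the source may bear on it.

In a functional assay on L1210 cells (Mus musculus) for inhibition, read by MTT assay, with a stated time of 72 h (on this read-out higher numbers stand for weaker inhibition and lower numbers for stronger inhibition), compound 2 `COc1cc(NC(C)CCCNC(=O)Nc2cccc(O)c2)c2ncccc2c1` gives 25000 nM. Compound 1 `COc1cc(NC(C)CCCNC(=O)NNC(=O)Nc2ccc(C(F)(F)F)cc2)c2ncccc2c1` gives 18000 nM in this assay; the gap between these two numbers lies within the scatter, so neither compound is separated from the other. Compound 3 `COc1cc(NC(C)CCCNC(=O)NNC(=O)Nc2ccc(O)cc2)c2ncccc2c1` remains to be measured in this assay. It differs from compound 2 by ((4-hydroxyphenyl)carbamoyl)amino in place of 3-hydroxyphenyl on an amide-type nitrogen, a grouping that compound 1 also carries. Going by the values given here, no step between two measured compounds is available to lean on, so the expected change is a 1.3-fold lower number from compound 2 to compound 3 (0.10 log units; within the scatter), nothing beyond the scatter. Compound 3 is therefore estimated at 20000 nM, with a range from 8000 nM to 50000 nM.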

Compound 3, half-maximal inhibitory concentration: 95000 nM
The estimate for compound 3 lay 4.8-fold (0.68 log units) below the measured number, and the stated range ends below it.
By their numbers in this assay, from the lowest: compounds 1 and 2 (each within the scatter of the next); then compound 3.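

Hydroxy in place of trifluoromethyl on an aromatic carbon is the first change here to move the number beyond the scatter in this assay, giving a 5.3-fold higher number from compound 1 to compound 3 (0.72 log units; beyond the scatter). Swapping 3-hydroxyphenyl for ((4-hydroxyphenyl)carbamoyl)amino on an amide-type nitrogen also weakens inhibition, giving a 3.8-fold higher number from compound 2 to compound 3 (0.58 log units; beyond the scatter). Nothing available explains either step.

The shown compounds do not reveal how an amine or a methoxy group on that aromatic carbon would compare with hydroxy or trifluoromethyl. They also cannot separate the longer ((4-hydroxyphenyl)carbamoyl)amino group's added atoms from the different hydroxy placement in the second step.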